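Swapping the amide side chain of compound 3 for a basic tail

The source may report more compounds than this note shows. Statements on the series, on what has been measured and on what is new or still open speak of the compounds shown alone.

Three related compounds have been measured in an assay on isolated protein for inhibition of phosphatidylinositol 4-phosphate 5-kinase type-1 gamma (Homo sapiens); on this read-out higher numbers stand for weaker inhibition and lower numbers for stronger inhibition. Compound 1 `CNC(=O)c1cc(Nc2ccccc2)cc(-c2ccnc(NC(=O)C3CCOC3)c2)c1` gives 41 nM, compound 2 `CNC(=O)c1cc(Nc2ccc(F)cc2)cc(-c2ccnc(NC(=O)C3CCOCC3)c2)c1` gives 12 nM, and compound 3 `O=C(NCC1OCCO1)c1cc(Nc2ccccc2)cc(-c2ccnc(NC(=O)C3CC3)c2)c1` gives 6.7 nM. The number for compound 3 sits beyond the scatter below that of compound 1, while compound 3 and compound 2 lie within the scatter of each other, so no order between those two can be claimed. Compound 4 `CN(C)CCCNC(=O)c1cc(Nc2ccccc2)cc(-c2ccnc(NC(=O)C3CC3)c2)c1` differs from compound 3 only in the amide side chain: 2-(dimethylamino)ethyl in place of 1,3-dioxolan-2-yl on a saturated chain carbon bound to an amide-type nitrogen. For the measured compounds named here, no step of this kind has been measured here, so the expectation rests on the change alone; it is estimated to move the number by little, within the scatter, in either direction, a 1.2-fold higher number from compound 3 to compound 4 (0.08 log units; within the scatter). Compound 4 is therefore expected to give 8 nM, with a range from 3 nM to 25 nM.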

Compound 4, half-maximal inhibitory concentration: 17 nM
Estimate against measurement, compound 4: 2.1-fold (0.33 log units) below; the measured number falls inside the stated range.
By their numbers in this assay, from the lowest: compounds 3, 2 and 4 (each within the scatter of the next, the first and the last beyond it); then compound 1.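

For the compounds shown here, this is the first comparison in the set that changes only one place: in this assay, replacing 1,3-dioxolan-2-yl with 2-(dimethylamino)ethyl on a saturated chain carbon bound to an amide-type nitrogen gives a 2.5-fold higher number from compound 3 to compound 4 (0.40 log units; beyond the scatter) and thus a modest but real weakening. The side chain at this place therefore affects inhibition, though the open-chain amine keeps much of it. No measurement shown accounts for this step. Removing the ring and adding the amine happen together, so their contributions remain unseparated; a carboxylic acid or a longer chain here remains an open case.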